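A few compounds are considered here, and "the series" means these few. Any claim that something is new, unique, unknown or untested is made for them only; others in the source may bear on it.

Within the data shown here, compound 1 `c1ccc(-c2n[nH]c(-c3ccccc3)n2)cc1` is the anchor of the pair measured so far: in a functional assay on the whole organism (Cricetulus griseus) with Cricetinae gen. sp. as the target (a lower number here means that less compound is needed, a higher number that more compound is needed for the effect), compound 1 gives 6 mg/kg, the only number obtained in this set. Compound 2 `Cc1cccc(-c2n[nH]c(-c3ccccc3)n2)c1` carries a methyl in place of hydrogen on an aromatic carbon of the shared core; in this assay compound 2 gives > 20 mg/kg, which is a limit of the assay. That methyl step is an at least 3.3-fold higher number from compound 1 to compound 2 (0.52 log units; beyond the scatter), resting on (the limit of > 20 mg/kg in this assay, at which 1 of the 2 values shown sits). Compound 3 `Cc1ccc(-c2n[nH]c(-c3ccccc3)n2)cc1` is the remaining methyl variant of compound 1: methyl in place of hydrogen on an aromatic carbon. Among the measured compounds shown here, the one measured step that bears on it is the methyl step from compound 1 to compound 2, which pushed the dose upward beyond the scatter. A shift in the same direction is therefore expected for compound 3, of modest size, though the place of the methyl differs and the outcome need not repeat. Compound 3 is estimated at 15 mg/kg in this assay, between 6 mg/kg and 40 mg/kg. That estimate corresponds to an expected step of a 2.5-fold higher number from compound 1 to compound 3 (0.40 log units; beyond the scatter).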

Compound 3, dose for half-maximal effect: > 20 mg/kg
Compound 3 gave a limit, no number; the forecaster's own chance of this, stated with the estimate: 40%; middle value at least 1.3-fold (0.12 log units) away from the limit.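

With the methyl para to a large group, on an aromatic carbon of a six-membered aromatic ring of carbon only, the replacement of hydrogen again gives an at least 3.3-fold higher number from compound 1 to compound 3 (0.52 log units; beyond the scatter), so among the compounds shown the rise seen with compound 2 is not tied to that compound's methyl place alone. In this assay compound 3 gives > 20 mg/kg, which is a limit and not a number, and it is the same limit that compound 2 reaches. The two methyl places therefore cannot be ranked against each other, and the true size of either step cannot be read: the limit of > 20 mg/kg in this assay, at which 2 of the 3 values shown sit.

On these data alone, it remains open whether any other group at this place, such as a chlorine atom, a methoxy group, an amine or a carboxylic acid, would keep the dose close to that of compound 1 at 6 mg/kg. Also open, as far as these compounds go, is whether the rise belongs to methyl specifically or extends to a longer chain such as ethyl, and how a substituent on the second phenyl ring of the shared core would behave.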